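Three side chains level; a fourth at the same position

The compounds below may be only part of what the source reports. "The series", "measured", "known", "first", "only" and "open" are said of these compounds alone.

Compound 3 `NC(=O)C[C@H](NC(=O)CN(c1ncnc2c1ncn2C1CCCCO1)C1CC1)C(=O)OCc1ccccc1` gives 29.2% in a functional assay on the whole organism (Tail, strain ICR) with Mus musculus as the target, in the tail flick test, with a stated time of 120 min, at a dose of 25 umol/kg by the oral route (a lower number here means a weaker effect, a higher number a stronger effect of the compound at the dose given), and stands level with compound 1 `O=C(CN(c1ncnc2c1ncn2C1CCCCO1)C1CC1)N[C@@H](CO)C(=O)OCc1ccccc1`, which gives 29.2%; together these two are the highest of the three numbers, and compound 2 `CSCC[C@H](NC(=O)CN(c1ncnc2c1ncn2C1CCCCO1)C1CC1)C(=O)OCc1ccccc1`, which gives 28.7%, lies nearest below. All three steps are within the scatter: a number 0.5 percentage points lower from compound 1 to compound 2 (within the scatter), no change at the digits printed from compound 1 to compound 3 (within the scatter) and a number 0.5 percentage points higher from compound 2 to compound 3 (within the scatter). The side chain on the saturated chain carbon between the amide-type nitrogen and the carbonyl carbon has therefore been changed three ways without any shift in this assay .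

Compound 4 `C[C@@H](O)[C@H](NC(=O)CN(c1ncnc2c1ncn2C1CCCCO1)C1CC1)C(=O)OCc1ccccc1` changes this same position again: 1-hydroxyethyl in place of carbamoylmethyl on a saturated chain carbon bound to an amide-type nitrogen and a carbonyl carbon. The three measured steps bear on this change in that each exchanged the group at this place, and none moved the read-out beyond the scatter. No step beyond the scatter is therefore expected here either; the estimated step is a number 0.2 percentage points lower from compound 3 to compound 4 (within the scatter). Compound 4 is estimated to give 29% in this assay , with a range from 20% to 38%.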

Compound 4, a percentage reported as activity, at one dose (the size of the read-out at that dose, not a potency): 10.9%
Compound 4: the middle estimate sits 18.1 percentage points above what was measured, and the stated range ends above it.
By their numbers in this assay, from the lowest: compound 4; then compounds 2, 1 and 3 (each within the scatter of the next).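

In this assay, this position is no longer without effect: 1-hydroxyethyl in place of carbamoylmethyl gives a number 18.3 percentage points lower from compound 3 to compound 4 (beyond the scatter), and 1-hydroxyethyl in place of 2-(methylsulfanyl)ethyl gives a number 17.8 percentage points lower from compound 2 to compound 4 (beyond the scatter). The hydroxy group alone does not go with the low number, since methyl in place of hydrogen on the saturated chain carbon bound to an oxygen on a saturated carbon gives a number 18.3 percentage points lower from compound 1 to compound 4 (beyond the scatter), and this one added methyl is enough to separate two compounds that both carry a hydroxy side chain. No measurement offered here accounts for this drop.

The compounds shown leave open whether the low number goes with the branched chain itself, which an isopropyl group would test without the hydroxy. They also leave open whether it depends on the defined stereocentre of 1-hydroxyethyl, which the opposite configuration at that carbon would test.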